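From 2-Acetoxyethyl to (Furan-2-yl)carbonyl at One Oxygen

The source may hold more compounds than are shown below. What is called first, only, known or untested is meant among the compounds shown, and "the series" means these compounds.

Compound 1 `CC(=O)OCCO[C@H](CC=C(C)C)C1=CC(=O)c2c(O)ccc(O)c2C1=O` carries a 2-acetoxyethyl group on an oxygen on a saturated carbon of the shared core. In a functional assay on DU-145 cells (Homo sapiens) for cytotoxicity, read by MTT assay (a higher number here means a weaker inhibitor, a lower number a stronger inhibitor), compound 1 gives 15500 nM, the lowest of the three numbers measured, though its neighbours sit close: compound 2 `CCC(C)(O)CC(=O)O[C@H](CC=C(C)C)C1=CC(=O)c2c(O)ccc(O)c2C1=O` gives 16000 nM and compound 3 `CC[C@](C)(O)CC(=O)O[C@H](CC=C(C)C)C1=CC(=O)c2c(O)ccc(O)c2C1=O` gives 20500 nM. The steps of a 1.0-fold higher number from compound 1 to compound 2 (0.01 log units; within the scatter) and a 1.3-fold higher number from compound 1 to compound 3 (0.12 log units; within the scatter) both fall within the scatter, and a 1.3-fold higher number from compound 2 to compound 3 (0.11 log units; within the scatter) does likewise; the last pair differ only in that (the fact that one of compounds 2 and 3 is drawn with a defined configuration and the other without, at the place where they differ).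

Compound 4 `CC(C)=CC[C@@H](OC(=O)c1ccco1)C1=CC(=O)c2c(O)ccc(O)c2C1=O` alters the same oxygen: (furan-2-yl)carbonyl in place of 2-acetoxyethyl on an oxygen on a saturated carbon. The measured steps that bear on it are those that put a (2-hydroxy-2-methylbutyl)carbonyl ester in place of the 2-acetoxyethyl group at that oxygen, and neither moved the number beyond the scatter. An ester at this oxygen has so far left this assay essentially unchanged, so compound 4 is expected to show no step beyond the scatter, a 1.1-fold higher number from compound 1 to compound 4 (0.04 log units; within the scatter). The estimate for compound 4 in this assay is 17000 nM, with a range from 7000 nM to 40000 nM.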

Compound 4, half-maximal inhibitory concentration: > 100000 nM
Compound 4: no number, only a limit (the forecaster's own chance of this, stated with the estimate: 5%); at least 5.8-fold (0.76 log units) between middle value and limit.
By their numbers in this assay, from the lowest: compounds 1, 2 and 3 (each within the scatter of the next). At a limit, above all of these: compound 4.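

In this assay compound 4 gives > 100000 nM, which is a limit of the assay and not a number. The position is therefore not indifferent to what it carries: the earlier changes at this oxygen all stayed within the scatter, whereas (furan-2-yl)carbonyl in place of 2-acetoxyethyl gives an at least 6.4-fold higher number from compound 1 to compound 4 (0.80 log units; beyond the scatter). An ester link alone does not settle the outcome, as the group on the carbonyl carbon also counts: furan-2-yl in place of 2-hydroxy-2-methylbutyl gives an at least 6.2-fold higher number from compound 2 to compound 4 (0.79 log units; beyond the scatter) and an at least 4.8-fold higher number from compound 3 to compound 4 (0.68 log units; beyond the scatter), both beyond the scatter.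

As far as these compounds go, the true size of these steps stays open because compound 4 rests at a limit and not at a measured number: the limit of > 100000 nM in this assay, at which 1 of the 4 values shown sits. Also open, from the compounds shown here alone, is what in the furan-2-yl group carries the change, that is, whether a phenyl ring, a saturated tetrahydrofuran-2-yl ring or a plain methyl group on the same carbonyl carbon would leave the number close to those of compounds 1, 2 and 3 or would move it towards the limit seen for compound 4.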